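Working notes: adding methoxy to compound 3

A few compounds are considered here, and "the series" means these few. Any claim that something is new, unique, unknown or untested is made for them only; others in the source may bear on it.

Values in a functional assay on MDA-MB-231 cells (Homo sapiens) for inhibition, with a stated time of 72 h (on this read-out higher numbers stand for weaker inhibition and lower numbers for stronger inhibition), for the series so far
- compound 1 `COc1ccc(NC(=O)Nc2nc(Sc3c[nH]c4ccccc34)cc(N3CCN(c4ccccn4)CC3)n2)cc1` gives 28400 nM
- compound 2 `O=C(Nc1ccccc1)Nc1nc(NC2CC2)cc(Sc2c[nH]c3ccccc23)n1` gives 7860 nM
- compound 3 `O=C(Nc1ccccc1)Nc1nc(Sc2c[nH]c3ccccc23)cc(N2CCCC2)n1` gives 7890 nM

Compound 3 sits with compound 2 among the three numbers, within the scatter of it, and lies below compound 1 by a margin beyond the scatter. Compound 4 `COc1ccc(NC(=O)Nc2nc(Sc3c[nH]c4ccccc34)cc(N3CCCC3)n2)cc1` has methoxy in place of hydrogen on an aromatic carbon, para to a large group methoxy in place of hydrogen on an aromatic carbon in the change from compound 3. Among the measured compounds shown here, the only measured step, a 1.0-fold higher number from compound 2 to compound 3 (0.00 log units; within the scatter), swaps cyclopropylamino for pyrrolidin-1-yl and does not touch that place. Compound 1 carries the same 4-methoxyphenyl, but it also differs at the other group, so its 28400 nM cannot isolate methoxy. That value still points to a small move toward a higher number, possibly none beyond the scatter. The expected step is a 1.3-fold higher number from compound 3 to compound 4 (0.12 log units; within the scatter) in this assay for now. For compound 4 the estimated value is 10500 nM, with an expected range from 4500 nM to 25000 nM in this assay for now.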

Compound 4, half-maximal inhibitory concentration: 13100 nM
Beside the measured number, compound 4's estimate is 1.2-fold (0.10 log units) below it; measured number inside the range.
By their numbers in this assay, from the lowest: compounds 2, 3 and 4 (each within the scatter of the next); then compound 1.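

In this assay the change from phenyl to 4-methoxyphenyl now has its own reading, with a 1.7-fold higher number from compound 3 to compound 4 (0.22 log units; within the scatter) as the isolated step, so methoxy on this aromatic carbon does not separate from hydrogen. Among the compounds shown here, with the 4-methoxyphenyl held constant, the other group can also be read alone, and a 2.2-fold lower number from compound 1 to compound 4 (0.34 log units; beyond the scatter) gives a modest step for that exchange, which the earlier compounds could not isolate from the methoxy change. No measurement here accounts for the size of either step.

The compounds shown leave open whether a carboxylic acid or an amine in place of methoxy on this ring would give a step beyond the scatter. On these data alone, it also remains open whether the exchange of 4-(pyridin-2-yl)piperazin-1-yl for pyrrolidin-1-yl gives a similar step when the urea carries plain phenyl.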